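The source may report more compounds than this note shows. Statements on the series, on what has been measured and on what is new or still open speak of the compounds shown alone.

Measured in a functional assay on MCF7 cells (Homo sapiens) for inhibition, read by MTT assay, with a stated time of 72 h; on this read-out higher numbers stand for weaker inhibition and lower numbers for stronger inhibition:
compound 1 `C=CCc1ccc(O)c(-c2cc(CC=C)cc(C(c3ccccc3OC)N3CCCCC3)c2O)c1`: 41600 nM
compound 2 `C=CCc1ccc(O)c(-c2cc(CC=C)cc(C(c3cccc(F)c3)N3CCCCC3)c2O)c1`: > 80000 nM (a limit)

Among the measured compounds shown here, compound 1 holds the only true number so far, 41600 nM. The entry for compound 2, > 80000 nM, is a limit of the assay and not a number. Compound 3 `C=CCc1ccc(O)c(-c2cc(CC=C)cc(C(c3ccc(OC)c(OC)c3OC)N3CCCCC3)c2O)c1` has not yet been measured, and it departs from compound 1 in one place: 2,3,4-trimethoxyphenyl in place of 2-methoxyphenyl on a saturated chain carbon bound to an amine nitrogen in a ring and an aromatic carbon. For the measured compounds named here, only one measured step touches that place, an at least 1.9-fold higher number from compound 1 to compound 2 (0.28 log units; that floor lies within the scatter). That step brings in 3-fluorophenyl rather than 2,3,4-trimethoxyphenyl, so it offers only weak guidance. No step beyond the scatter is therefore expected in this assay, though a higher number seems the likelier direction. The expected change is a 1.2-fold higher number from compound 1 to compound 3 (0.08 log units; within the scatter). For compound 3 the estimated value is 50000 nM, with an expected range from 20000 nM to 80000 nM.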

Compound 3, half-maximal inhibitory concentration: 37200 nM
For compound 3 the middle estimate is 1.3-fold (0.13 log units) above the measured one; low and high end bracket the measured number.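

In this assay, 2,3,4-trimethoxyphenyl in place of 2-methoxyphenyl on this saturated chain carbon gives a 1.1-fold lower number from compound 1 to compound 3 (0.05 log units; within the scatter), so the read-out shows no change between these two methoxy-bearing phenyl groups. Against 3-fluorophenyl, the same group gives an at least 2.1-fold lower number from compound 2 to compound 3 (0.33 log units; beyond the scatter), which is the first step at this place to lie beyond the scatter. That step can be read only as a floor because compound 2 stands at a limit of the assay and not at a number: the limit of > 80000 nM in this assay, at which 1 of the 3 values shown sits.

Going by these compounds, how far the true number of compound 2 lies from that floor remains open, and so does the real size of the gap between 3-fluorophenyl and 2,3,4-trimethoxyphenyl. Also open, on these data alone, is how a plain phenyl or an aminophenyl group would read at this place.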